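Working notes on cytotoxicity across compounds 1 to 4

The source may report more compounds than this note shows. Statements on the series, on what has been measured and on what is new or still open speak of the compounds shown alone.

Measured so far:
Compound 1 `CC(=O)OCc1cccc2c1CCOC2=O` gives > 2430000 nM in an ADME assay on HepG2 2.2.15 cells (Homo sapiens) for cytotoxicity, read by MTT assay, with a stated time of 72 h (a lower number here means that less compound is tolerated, a higher number that more compound is tolerated), a limit of the assay.
Compound 2 `CCC(CC)C(=O)OCc1cccc2c1CCOC2=O` gives 1890000 nM in this assay.
Compound 3 `O=C(OCc1cccc2c1CCOC2=O)c1cccnc1` gives > 2700000 nM in this assay, again a limit of the assay.

Compound 1 stands at the top of what has been read, known only as a limit, (the limit of > 2430000 nM in this assay, at which 1 of the 3 values shown sits). Compound 3 sits at a limit as well, (the limit of > 2700000 nM in this assay, at which 1 of the 3 values shown sits). The change to compound 4 `O=C1OCCc2c(/C=N\O)cccc21` is a group of 3 heavy atoms (1 carbon, 1 nitrogen, 1 oxygen; no ring) in place of a group of 5 heavy atoms (3 carbon, 2 oxygen; no ring), on an aromatic carbon. Going by the values given here, none of the measured steps touches this position in the same way; all three vary only the group on the carbonyl carbon of the ester, and all are small: an at least 1.2-fold lower number from compound 1 to compound 2 (0.10 log units; that floor lies within the scatter), an at least 1.4-fold higher number from compound 2 to compound 3 (0.15 log units; that floor lies within the scatter), and a step that the two limits leave unreadable from compound 1 to compound 3. Across the measured set no change has moved the read-out beyond the scatter, so nothing among these compounds points to a shift for compound 4 either. The step expected in this assay is an at least 1.0-fold lower number from compound 1 to compound 4 (0.00 log units; that floor lies within the scatter), none beyond the scatter, with a fair chance that only a limit is reported. Compound 4 is estimated at 2400000 nM, within 900000 nM to 6000000 nM.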

Compound 4, half-maximal cytotoxic concentration: > 4000000 nM
Compound 4: a limit, no number; the forecaster's own chance of this, stated with the estimate: 60%; middle value at least 1.6-fold (0.22 log units) away from the limit.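

In this assay compound 4 gives > 4000000 nM, a limit of the assay. Going by these compounds alone, compound 1 is also known only as a limit, so no step from compound 1 to compound 4 can be read. The compounds shown leave open whether replacing acetoxymethyl changes the read-out at all.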